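The source may hold more compounds than are shown below. What is called first, only, known or untested is meant among the compounds shown, and "the series" means these compounds.

Measured in a functional assay on SK-MEL-28 cells (Homo sapiens) for inhibition, read by MTT assay, with a stated time of 48 h; a higher number here means a weaker inhibitor, a lower number a stronger inhibitor:
- compound 1 `Cc1ccc(-c2nc3ccccn3c2Sc2ccccc2)cc1`: > 100000 nM
- compound 2 `c1ccc(Sc2c(-c3ccccc3)nc3ccc(-c4ccccc4)cn23)cc1`: > 100000 nM

Neither entry is a number. As far as these compounds go, compound 1 gives > 100000 nM, which is a limit of the assay, so its true position is unknown. Compound 2 gives > 100000 nM, also a limit. Together they make up the whole of the record so far: the limit of > 100000 nM in this assay, at which 2 of the 2 values shown sit.

Compound 3 `Clc1ccc(-c2nc3ccccn3c2Sc2ccccc2)cc1` keeps the core of compound 1 and changes one substituent, chloro in place of methyl on an aromatic carbon, 4-methylphenyl to 4-chlorophenyl: chloro in place of methyl on an aromatic carbon. Among the measured compounds shown here, no measured pair shows what such a change does. In this assay, no step beyond the usual scatter is therefore expected, and the expectation rests on compound 1 with its limit of > 100000 nM. The expected step is a number no higher from compound 1 to compound 3 (the limit leaves the size open). For compound 3 the estimated value is 100000 nM, with an expected range of 30000 nM to 200000 nM.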

Compound 3, half-maximal inhibitory concentration: 73100 nM
Compound 3: the middle estimate sits 1.4-fold (0.14 log units) above what was measured; low and high end bracket the measured number.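

Among the compounds shown here, compound 3 gives the first actual number in this assay, so a chloro on this aromatic carbon, para to a large group, brings the reading within the range of the assay. As far as these compounds go, the change from 4-methylphenyl to 4-chlorophenyl amounts to an at least 1.3-fold lower number from compound 1 to compound 3 (0.13 log units; that floor lies within the scatter), and since the value of compound 1 is only a limit, the true size of the step stays unknown and may or may not exceed the scatter. The single number also stands against a record still dominated by a limit: the limit of > 100000 nM in this assay, at which 2 of the 3 values shown sit.

The compounds shown leave open what an amine, a methoxy group or a carboxylic acid at this place would do. They also leave open whether chloro would give a similar step on a core carrying a further phenyl, as in compound 2.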